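Hydroxyethyl in Place of Phenyl on the Pyrazole Aryl

This account rests on a few compounds, and the source may have more. Where it says the series, first, only, none or still open, it means among the compounds named here.

Measured compounds:
compound 1 `CCCCc1c(-c2ccc(C(=O)NS(=O)(=O)c3ccc4ccccc4c3)cc2C(=O)N2CCc3ccccc3C2)c(C(=O)O)nn1-c1ccccc1` gives 170 nM
compound 2 `CCCCc1c(-c2ccc(C(=O)NS(=O)(=O)c3ccc4ccccc4c3)cc2C(=O)N2CCc3ccccc3C2)c(C(=O)OCC)nn1-c1cccc(Oc2ccccc2)c1` gives 140 nM
compound 3 `CCCCc1c(-c2ccc(C(=O)NS(=O)(=O)c3ccc4ccccc4c3)cc2C(=O)N2CCc3ccccc3C2)c(CO)nn1-c1ccc(-c2ccccc2)cc1` gives 7 nM

All three share a core and were tested in an assay on isolated protein for inhibition of Apoptosis regulator Bcl-2 (Homo sapiens), read by fluorescence polarization, with a stated time of 60 min; on this read-out lower numbers stand for stronger inhibition and higher numbers for weaker inhibition. Compound 3 stands lowest of the three numbers, and its gaps to compound 2 and to compound 1 both lie beyond the scatter, so it is the most potent of the measured set. Compound 1 and compound 2, which carry a carboxylic acid and an ethyl ester where compound 3 carries a hydroxymethyl, and which differ from it also in the aryl group on the pyrazole nitrogen, give the two higher values.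

Compound 4 `CCCCc1c(-c2ccc(C(=O)NS(=O)(=O)c3ccc4ccccc4c3)cc2C(=O)N2CCc3ccccc3C2)c(CO)nn1-c1ccc(CCO)cc1` keeps the hydroxymethyl of compound 3 and changes only the aryl: 2-hydroxyethyl in place of phenyl on an aromatic carbon. Going by the values given here, no step between two measured compounds isolates this change, so the size of its effect is not known from the data. Compound 3 shows that a larger aryl goes with the lowest value, and compound 1, with a plain phenyl, gives a much higher one, though other groups differ there too. The step of a 5.7-fold higher number from compound 3 to compound 4 (0.76 log units; beyond the scatter) is therefore expected to run toward weaker inhibition by a moderate amount. Compound 4 is estimated at 40 nM, with a range from 10 nM to 160 nM.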

Compound 4, half-maximal inhibitory concentration: 20 nM
Beside the measured number, compound 4's estimate is 2.0-fold (0.30 log units) above it; the measured number falls inside the stated range.
By their numbers in this assay, from the lowest: compound 3; then compound 4; then compounds 2 and 1 (each within the scatter of the next).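

Going by these compounds alone, the change from 4-phenylphenyl to 4-(2-hydroxyethyl)phenyl, with the hydroxymethyl and the rest of the shared core held fixed, gives a 2.9-fold higher number from compound 3 to compound 4 (0.46 log units; beyond the scatter) in this assay, the first reading of this position in which nothing else differs. The step is real but modest: it shows that the outer six-membered aromatic ring, para to a large group, can be replaced by a 2-hydroxyethyl chain with fewer heavy atoms at only a limited cost, and compound 4 still gives 20 nM. The data offer no explanation for the step, and they do not apportion it between the departing ring and the incoming hydroxyl.

The compounds shown leave that split open, since a plain ethyl group would separate the loss of the ring from the gain of the hydroxyl, while a longer chain such as 3-hydroxypropyl, or an amine or carboxylic acid at the end of the chain, would test what this position accepts. They also leave open whether the same change has a step of similar size when a carboxylic acid or ethyl ester stands in place of the hydroxymethyl.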